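Cyclobutylmethyl on the sulfonamide nitrogen of compound 3

The source may hold more compounds than are shown below. What is called first, only, known or untested is meant among the compounds shown, and "the series" means these compounds.

In a physicochemical assay for lipophilicity, at pH 7.4 (a lower number here means a more polar compound, a higher number a more lipophilic compound), compound 3 `CCc1ccc(NS(=O)(=O)c2ccc3c(c2)C(O)CC(C2CCOCC2)O3)cc1` gives 2.59. Compound 1 `CCc1ccc(N(C2COC2)S(=O)(=O)c2ccc3c(c2)C(O)CC(C2CCOCC2)O3)cc1` gives 2.63, which amounts to a number 0.04 log units lower from compound 1 to compound 3 (within the scatter), while compound 2 `CCc1ccc(N(C2CCC2)S(=O)(=O)c2ccc3c(c2)C(O)CC(C2CCOCC2)O3)cc1` gives 3.69. The next compound, compound 4 `CCc1ccc(N(CC2CCC2)S(=O)(=O)c2ccc3c(c2)C(O)CC(C2CCOCC2)O3)cc1`, has cyclobutylmethyl in place of hydrogen on a sulfonamide nitrogen. Among the measured compounds, compound 2 offers the nearest comparison, and its cyclobutyl group gives a number 1.10 log units lower from compound 2 to compound 3 (beyond the scatter), a large step here read in reverse. Oxetan-3-yl gives a step of similar size against cyclobutyl, a number 1.06 log units higher from compound 1 to compound 2 (beyond the scatter). A large upward step, similar to or somewhat beyond the cyclobutyl one, is therefore expected: a number 1.36 log units higher from compound 3 to compound 4 (beyond the scatter). For compound 4 the estimated value is 3.95, with an expected range from 3.5 to 4.4.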

Compound 4, distribution coefficient: 4.01
Compound 4: middle estimate off by 0.06 log units, on the low side; the measured number falls inside the stated range.
By their numbers in this assay, from the lowest: compounds 3 and 1 (each within the scatter of the next); then compound 2; then compound 4.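

Going by these compounds alone, on the sulfonamide nitrogen, cyclobutylmethyl gives the highest number so far in this assay, with a number 1.42 log units higher from compound 3 to compound 4 (beyond the scatter) and a number 1.38 log units higher from compound 1 to compound 4 (beyond the scatter) as the two large steps. The comparison with the directly attached ring, a number 0.32 log units higher from compound 2 to compound 4 (beyond the scatter), is modest but shows that this position still responds when the cyclobutyl ring is carried on one added carbon. Nothing available here explains these steps. On these data alone, whether a longer chain or an amine at this nitrogen would move the number further remains open.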